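Swapping selenium for sulfur on a bis-benzothiophene amidine

The source may hold more compounds than are shown below. What is called first, only, known or untested is meant among the compounds shown, and "the series" means these compounds.

Compound 1 (`C[Se]/C(=N\C(=O)c1cc2ccccc2s1)NC(=O)c1cc2ccccc2s1`) was tested in a functional assay on PC-3 cells (Homo sapiens) for cytotoxicity, read by MTT assay, with a stated time of 72 h (on this read-out lower numbers stand for higher toxicity in this test and higher numbers for lower toxicity in this test), where compound 1 gives 94000 nM. Compound 2 (`C[Se]/C(=N\C(=O)c1ccco1)NC(=O)c1ccco1`) belongs to the same series; in this assay compound 2 reaches only a limit of the assay and not a number, at > 100000 nM. For the measured compounds named here, compound 1 therefore holds the only measured number in this assay, with the one other value being a limit, as the limit of > 100000 nM in this assay, at which 1 of the 2 values shown sits, records.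

The piece now follows the step from compound 1 to compound 3 (`CS/C(=N\C(=O)c1cc2ccccc2s1)NC(=O)c1cc2ccccc2s1`). The change is a group of 2 heavy atoms (1 carbon, 1 sulfur; no ring) in place of a group of 2 heavy atoms (1 carbon, 1 selenium; no ring), on a carbon with a double bond to nitrogen. Going by the values given here, no measured pair in this study makes a comparable swap, so there is no step to lean on. On the numbers shown, the step from compound 1 to compound 3 is expected to be small, either within the scatter or slightly toward lower toxicity, with the result likely landing near the assay limit, as a 1.4-fold higher number from compound 1 to compound 3 (0.14 log units; within the scatter) expresses. Compound 3 is estimated at 130000 nM in this assay, within a range from 55000 nM to 300000 nM.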

Compound 3, concentration lethal to 50% of the cells: 72600 nM
Estimate against measurement, compound 3: 1.8-fold (0.25 log units) above; the measured number falls inside the stated range.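

In this assay, putting methylsulfanyl in place of the selenium-bearing group, on a carbon with a double bond to nitrogen, gives a 1.3-fold lower number from compound 1 to compound 3 (0.11 log units; within the scatter) and so leaves the two groups indistinguishable on this read-out. This is the first pair shown that differs in one place, and it shows that, on the core of compound 1, the selenium atom can be replaced by sulfur with no change beyond the scatter, so selenium is not required for the weak toxicity seen with compound 1 in this test. No measurement shown bears on why the two groups behave alike in this test.

The compounds shown leave open whether a different kind of group on the same carbon, such as an amine or a longer chain in place of methylsulfanyl, would move the number beyond the scatter. They also leave open whether the same exchange of selenium for sulfur would read the same way on the core of compound 2, whose value in this assay is a limit of the assay and not a number.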